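One Bromo Swapped for Hydrogen on a Tolerated Compound

This account rests on a few compounds, and the source may have more. Where it says the series, first, only, none or still open, it means among the compounds named here.

Compound 1 `Cc1ccc(-c2nn(-c3ccccc3)cc2CNc2ccccc2)cc1` gives 52000 nM
Compound 2 `Brc1ccc(NCc2cn(-c3ccccc3)nc2-c2ccc(Br)cc2)cc1` gives 88000 nM

Both numbers come from an ADME assay on Vero 76 cells (Chlorocebus sabaeus) for cytotoxicity, read by MTT assay, with a stated time of 96 h (a lower number here means that less compound is tolerated, a higher number that more compound is tolerated), a test of how much compound living cells can bear. There, compound 1 at 52000 nM and compound 2 at 88000 nM lie within the usual scatter of each other, so compound 2 stands level with compound 1 and the two cannot be ranked.

Compound 3 `Brc1ccc(-c2nn(-c3ccccc3)cc2CNc2ccccc2)cc1` has not been measured yet. It differs from compound 2 by a single change (hydrogen in place of bromo on an aromatic carbon), with hydrogen in place of bromo on an aromatic carbon, which turns (4-bromophenyl)amino into anilino. Going by the values given here, no measured pair here shows this change on its own, so the data give no direct size for it. With so little to go on, a small move toward a lower number in this assay is expected, most likely none beyond the scatter. The estimated step runs a 1.4-fold lower number from compound 2 to compound 3 (0.13 log units; within the scatter) and is expected to be modest. For compound 3 the estimate is 65000 nM, with an expected range from 30000 nM to 130000 nM.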

Compound 3, half-maximal cytotoxic concentration: 52000 nM
The estimate for compound 3 lay 1.3-fold (0.10 log units) above the measured number; the range from low to high includes it.
By their numbers in this assay, from the lowest: compounds 1, 3 and 2 (each within the scatter of the next).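

In this assay, removing the bromo from the (4-bromophenyl)amino group to leave anilino gives a 1.7-fold lower number from compound 2 to compound 3 (0.23 log units; within the scatter), so this single change cannot be told apart from the ordinary spread of repeated measurements. The new compound also allows a second one-place comparison, on the other side of the molecule, where bromo in place of methyl on an aromatic carbon gives no change at the digits printed from compound 1 to compound 3 (within the scatter); thus neither swap, at its own position, produces a difference that this test can resolve. No further data bear on what lies behind these two results.

These compounds leave open whether the flat picture holds only for small, uncharged swaps of hydrogen, bromo and methyl, since each comparison covers just one pair at one position. An amine or a carboxylic acid on either aromatic ring, or a longer chain in place of the anilinomethyl link, would test whether cells tolerate the shared core equally well when it carries a very different kind of group.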